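The source may hold more compounds than are shown below. What is called first, only, known or untested is meant among the compounds shown, and "the series" means these compounds.

Of the compounds shown here, three have so far been tested in an ADME assay on Vero cells (Chlorocebus sabaeus) for cytotoxicity, with a stated time of 7 days; on this read-out lower numbers stand for higher toxicity in this test and higher numbers for lower toxicity in this test. Compound 1 `COc1cccc(CN2C(=O)CN(C(=O)c3cc4cc(OC)ccc4[nH]3)C[C@@H]2COCc2ccccc2)c1` returns only a limit of the test, > 10000 nM, which is the limit of > 10000 nM in this assay, at which 1 of the 3 values shown sits. Compound 2 `COc1ccc2[nH]c(C(=O)N3CC(=O)N(Cc4ccccc4)[C@@H](CN4CCC(C)CC4)C3)cc2c1` likewise returns only a limit in this assay, > 30000 nM. Compound 3 `COc1ccc2[nH]c(C(=O)N3CC(=O)N(Cc4ccccc4)[C@@H](N4CCC(Cc5ccccc5)CC4)C3)cc2c1` also stops at a limit in this assay, > 30000 nM. Two of the three values thus sit at the limit of > 30000 nM in this assay, at which 2 of the 3 values shown sit, so no number separates any pair of them, and compound 2 stands where its companions stand: at a limit, with no cytotoxicity detected inside the range of the test. For the measured compounds named here, no step between measured compounds that differ in one place is available.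

Compound 4 `COc1ccc2[nH]c(C(=O)N3CC(=O)N(Cc4ccccc4)[C@@H](CN4CC5CCCC5C4)C3)cc2c1` differs from compound 2 by a single change: a group of 8 heavy atoms (7 carbon, 1 nitrogen; one five-membered non-aromatic ring of carbon only, one five-membered non-aromatic ring with 1 hetero atom) in place of a group of 7 heavy atoms (6 carbon, 1 nitrogen; one six-membered non-aromatic ring with 1 hetero atom), on a saturated chain carbon bound to a saturated ring carbon. The three measured compounds give no indication that such a swap would move the read-out in this assay, and the expectation for the step from compound 2 to compound 4 is none beyond the scatter, a step that the limit leaves unreadable from compound 2 to compound 4. Compound 4 is therefore expected to give 40000 nM in this assay, within a range from 15000 nM to 100000 nM, and it is most likely that the test will again report only a limit rather than a number.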

Compound 4, half-maximal cytotoxic concentration: 10600 nM
Beside the measured number, compound 4's estimate is 3.8-fold (0.58 log units) above it; measured number below the stated range.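

In this assay, the exchange of 4-methylpiperidin-1-yl for the group with one five-membered non-aromatic ring of carbon only and one five-membered non-aromatic ring with 1 hetero atom, on a saturated chain carbon bound to a saturated ring carbon, gives an at least 2.8-fold lower number from compound 2 to compound 4 (0.45 log units; beyond the scatter). This shows that the read-out is not indifferent to the group at this place: a change confined to it is enough to bring a number inside the range of the test, on the side of higher toxicity in this test. The true size of the step stays unknown, and the printed figure is only a lower bound because compound 2 stops at a limit: the limit of > 30000 nM in this assay, at which 2 of the 4 values shown sit.

For the compounds shown here, the single step cannot separate the effect of the pair of five-membered rings from that of the size of the group, and a morpholin-4-yl or an open-chain diethylamino group on the same carbon would bear on that question. The compounds shown also leave open whether the same exchange would lower the number with other groups elsewhere on the shared core.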